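The source may hold more compounds than are shown below. What is called first, only, known or untested is meant among the compounds shown, and "the series" means these compounds.

Of the compounds shown here, two of a shared core have been measured in an assay on LM cells for displacement of a labelled ligand from Neuropeptide Y receptor type 5 (Homo sapiens); on this read-out higher numbers stand for weaker inhibition and lower numbers for stronger inhibition. Compound 1 `Fc1ccc(C2(c3ccc(F)cc3)CNC(c3cccs3)=N2)cc1` carries a thiophen-2-yl group on the carbon with a double bond to nitrogen, and in this assay compound 1 gives 54 nM. Compound 2 `Fc1ccc(C2(c3ccc(F)cc3)CNC(c3cccnc3)=N2)cc1` differs from it in one place, pyridin-3-yl in place of thiophen-2-yl on a carbon with a double bond to nitrogen, and in this assay compound 2 gives 7.2 nM. On the numbers shown, compound 2 stands lowest of the two, and the step of a 7.5-fold lower number from compound 1 to compound 2 (0.88 log units; beyond the scatter) lies beyond the scatter. Compound 3 `Fc1ccc(C2(c3ccc(F)cc3)CNC(c3ccncc3)=N2)cc1` is not yet measured; it differs from compound 2 by pyridin-4-yl in place of pyridin-3-yl on a carbon with a double bond to nitrogen. Among the compounds with values here, no measured step bears on a shift of the ring nitrogen alone, so no direction can be read from the data. Compound 3 is therefore expected to give about 11 nM in this assay, within a range of 3 nM to 40 nM, which is estimated to correspond to a 1.5-fold higher number from compound 2 to compound 3 (0.18 log units; within the scatter).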

Compound 3, half-maximal inhibitory concentration: 160 nM
Estimate against measurement, compound 3: 15-fold (1.16 log units) below; measured number above the stated range.
By their numbers in this assay, from the lowest: compound 2; then compound 1; then compound 3.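

At the carbon with a double bond to nitrogen, the place of the nitrogen within the six-membered aromatic ring matters strongly in this assay: with the same atoms joined differently, pyridin-4-yl in place of pyridin-3-yl gives a 22-fold higher number from compound 2 to compound 3 (1.35 log units; beyond the scatter). A pyridine ring as such therefore does not lower the number relative to thiophen-2-yl, since pyridin-4-yl gives a 3.0-fold higher number from compound 1 to compound 3 (0.47 log units; beyond the scatter), the opposite direction to the earlier step to pyridin-3-yl. Nothing available accounts for this difference between the two pyridine attachments.

The compounds shown leave open where pyridin-2-yl or an unsubstituted phenyl ring would fall at this position. Also open, on these data alone, are whether an amine or a methoxy group on the pyridin-3-yl ring would keep the number of compound 2, and whether the same order holds with other groups in place of the two 4-fluorophenyl groups.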